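The compounds below may be only part of what the source reports. "The series", "measured", "known", "first", "only" and "open" are said of these compounds alone.

Of the compounds shown here, three sharing one core have been tested in an ADME assay on MDBK cells (Bos taurus) for cytotoxicity; a higher number here means that more compound is tolerated, a lower number that less compound is tolerated: compound 1 `Cc1cccc(Cn2ccc3nc(-c4ccccc4)nc-3c2)c1`, compound 2 `Fc1cccc(Cn2ccc3nc(-c4ccccc4)nc-3c2)c1` and compound 3 `Brc1ccccc1Cn1ccc2nc(-c3ccccc3)nc-2c1`. Compound 1 gives > 100000 nM, which is a limit and not a number. Compound 2 gives > 100000 nM, again a limit. Compound 3 gives > 100000 nM, also only a limit, and that is all that is known of where it stands.

The step followed here leads to compound 4 `N#Cc1ccccc1Cn1ccc2nc(-c3ccccc3)nc-2c1`, with cyano in place of bromo on an aromatic carbon, ortho to a large group: cyano in place of bromo on an aromatic carbon. The measured steps that bear on it are a step that the two limits leave unreadable from compound 1 to compound 3, a step that the two limits leave unreadable from compound 2 to compound 3 and a step that the two limits leave unreadable from compound 1 to compound 2. None of them has a readable size because of the limit of > 100000 nM in this assay, at which 3 of the 3 values shown sit. Among the measured compounds shown here, they offer no measured size for the exchange of bromo for cyano, and no compound in the set has yet given a number in this assay.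

From compound 3, whose > 100000 nM is a limit, no step beyond the scatter is expected. The expected change is a number no higher from compound 3 to compound 4 (the limit leaves the size open). Compound 4 is most likely to be reported as a limit again, and its estimated value is 100000 nM, with an expected range from 40000 nM to 200000 nM.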

Compound 4, half-maximal cytotoxic concentration: > 100000 nM
Compound 4: a limit, no number; the forecaster's own chance of this, stated with the estimate: 85%; the middle value sits exactly at the limit.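

Compound 4 also yields only a limit in this assay, and its steps from compound 1, compound 2 and compound 3 cannot be read because every value shown is that same limit: the limit of > 100000 nM in this assay, at which 4 of the 4 values shown sit.

The compounds shown leave open how much compound of any of these four this assay would register as a number, and whether the exchange of bromo for cyano changes it at all.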